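From 4-Methylphenyl to 3-Methoxyphenyl on the Amide Nitrogen

A few compounds are considered here, and "the series" means these few. Any claim that something is new, unique, unknown or untested is made for them only; others in the source may bear on it.

Of the compounds shown here, three sharing one core have been tested in a functional assay on HeLa cells (Homo sapiens) for antiproliferative activity, read by MTT assay, with a stated time of 72 h; a lower number here means a stronger inhibitor, a higher number a weaker inhibitor. Compound 1 `Cc1ccc(N2C(=O)COc3ccc(-c4cnc5ccccc5c4)cc32)cc1` gives > 40000 nM, which is a limit of the measurement rather than a number. Compound 2 `O=C1COc2ccc(-c3ccc(O)cc3)cc2N1` likewise reaches only > 40000 nM, again a limit. Compound 3 `O=C1COc2ccc(-c3cnc(Cl)c(NS(=O)(=O)c4ccc(F)cc4)c3)cc2N1C1CCCCC1` gives 14300 nM. Compound 1 thus stands at the limit of > 40000 nM in this assay, at which 2 of the 3 values shown sit. Compound 4 `COc1cccc(N2C(=O)COc3ccc(-c4cnc5ccccc5c4)cc32)c1` is the next case: 3-methoxyphenyl in place of 4-methylphenyl on an amide-type nitrogen in a ring. Going by the values given here, no pair of measured compounds differing in a single place exists here, so no measured step guides this change. The step in this assay is expected to be small, within the scatter, in no clear direction. Compound 4 is therefore expected to give 40000 nM, between 15000 nM and 80000 nM. The estimated step is a number no higher from compound 1 to compound 4 (the limit leaves the size open).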

Compound 4, half-maximal inhibitory concentration: 11400 nM
The estimate for compound 4 lay 3.5-fold (0.55 log units) above the measured number; measured number outside the range, below it.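

This is the first single-place change shown, and it shows that the group on the amide-type nitrogen affects the read-out in this assay: 3-methoxyphenyl in place of 4-methylphenyl gives an at least 3.5-fold lower number from compound 1 to compound 4 (0.54 log units; beyond the scatter). That step has only one bound, and its true size stays open, since compound 1 sits at a limit: the limit of > 40000 nM in this assay, at which 2 of the 4 values shown sit.

Both the group and its place on the phenyl ring change here, so the compounds shown do not separate the two. As far as these compounds go, how an amine or a carboxylic acid on that phenyl ring would behave also remains open.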